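Compound 2: from cyclopentyl to 3,3,3-trifluoropropyl

A few compounds are considered here, and "the series" means these few. Any claim that something is new, unique, unknown or untested is made for them only; others in the source may bear on it.

Results so far in an ADME assay on microsomes from liver (Rattus norvegicus) for metabolic stability, with a stated time of 30 min, tested at 1 uM (on this read-out higher numbers stand for a more stable compound and lower numbers for a less stable compound), for three compounds:
- compound 1 `CC[C@@H]1C(=O)N(C)c2cnc(-n3ccnc3-c3ccc(F)cc3)nc2N1[C@H]1CCOC1` gives 67% remaining
- compound 2 `CC[C@@H]1C(=O)N(C)c2cnc(-n3ccnc3-c3ccccc3)nc2N1C1CCCC1` gives 0% remaining
- compound 3 `CC[C@@H]1C(=O)N(C)c2cnc(-n3ccnc3-c3ccc(F)cc3)nc2N1C1COC1` gives 80% remaining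

Compound 2 stands lowest of the three, well beyond the scatter from the other two. Compound 4 `CC[C@@H]1C(=O)N(C)c2cnc(-n3ccnc3-c3ccccc3)nc2N1CCC(F)(F)F` changes it in one place: 3,3,3-trifluoropropyl in place of cyclopentyl on a nitrogen on an aromatic ring in a ring and so has no ring there. Among the measured compounds shown here, the only measured step at this place, a number 13 percentage points higher from compound 1 to compound 3 (beyond the scatter) is modest, but it swaps one ring for another, and no measured step replaces a ring with a chain. Because compound 2 gives 0% the number cannot fall further, so a rise of uncertain size is expected. The estimated step is a number 25 percentage points higher from compound 2 to compound 4 (beyond the scatter) in this assay overall. The expected value for compound 4 is 25% (range 5% to 55%).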

Compound 4, percent of the compound remaining: 0%
For compound 4 the middle estimate is 25 percentage points above the measured one, and the stated range ends above it.
By their numbers in this assay, from the lowest: compounds 2 and 4 (each within the scatter of the next); then compound 1; then compound 3.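

In this assay there is no change at the digits printed from compound 2 to compound 4 (within the scatter), so replacing the cyclopentyl ring with the 3,3,3-trifluoropropyl chain leaves the read-out unmoved. On the core of compound 2, then, removing the ring and adding fluorine at this position does not lift the number off the bottom of the scale. Nothing available explains this result.

A read-out at the bottom of its scale cannot tell whether either compound is the less stable one. As far as these compounds go, it remains open whether a 2-methoxyethyl chain on this nitrogen would raise the number on that core.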